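The source may hold more compounds than are shown below. What is called first, only, known or untested is meant among the compounds shown, and "the series" means these compounds.

Going by the values given here, compound 2 `Cc1ccc2[nH]c(C(=O)NCc3cccc(Cn4cnc5ccccc54)c3)cc2c1` gives the higher of the two numbers measured so far in an assay for inhibition of Indoleamine 2,3-dioxygenase 1 (Homo sapiens), read by HPLC, with a stated time of 48 h (a lower number here means a stronger inhibitor, a higher number a weaker inhibitor), namely 636 nM. Among the compounds with values here, its closest relative is compound 1 `O=C(NCc1cccc(Cn2cnc3ccccc32)c1)c1cc2ccccc2[nH]1`, which in this assay gives 72 nM; the only measured step, an 8.8-fold higher number from compound 1 to compound 2 (0.95 log units; beyond the scatter), is a change of a single methyl. Compound 3 `O=C(NCc1cccc(Cn2cnc3ccccc32)c1)c1ccc(Cl)cc1` is a different kind of change: 4-chlorophenyl in place of 5-methyl-1H-indol-2-yl on a carbonyl carbon. The whole bicyclic group that carries the amide is exchanged for a single ring with a chlorine, and the hydrogen-bond donor of that group is lost. Within the data shown here, no measured step concerns such an exchange, so the one known step gives no direction for it. The estimate for compound 3 in this assay is therefore wide, centred on 1200 nM with a range from 200 nM to 8000 nM, which corresponds to an expected step of a 1.9-fold higher number from compound 2 to compound 3 (0.28 log units; within the scatter).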

Compound 3, half-maximal inhibitory concentration: 477 nM
Compound 3: middle estimate off by 2.5-fold (0.40 log units), on the high side; the measured number falls inside the stated range.
By their numbers in this assay, from the lowest: compound 1; then compounds 3 and 2 (each within the scatter of the next).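

In this assay, a single ring carrying chlorine can take the place of the whole 5-methyl-1H-indol-2-yl group on the carbonyl carbon with no change beyond the scatter (a 1.3-fold lower number from compound 2 to compound 3 (0.12 log units; within the scatter)), even though the hydrogen-bond donor of that group is gone. The same 4-chlorophenyl group does not match the unsubstituted 1H-indol-2-yl group, however (a 6.6-fold higher number from compound 1 to compound 3 (0.82 log units; beyond the scatter)), so the exchange costs something or nothing depending on which indole group it replaces. Nothing available explains either result.

Still open, from the compounds shown here alone, is whether the chlorine matters at all, which plain phenyl on the same carbonyl carbon would test. Also open, going by these compounds, is whether 5-chloro-1H-indol-2-yl would behave like the 5-methyl group or like the unsubstituted one.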